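This account rests on a few compounds, and the source may have more. Where it says the series, first, only, none or still open, it means among the compounds named here.

Compound 1 (`CC(=O)Nc1ccc(NC(=O)c2cc(Cl)ccc2O)c(Cl)c1`) and compound 2 (`O=C(Nc1ccc(NCc2ccco2)cc1Cl)c1cc(Cl)ccc1O`) share a core and have both gone through an ADME assay on A549 cells (Homo sapiens) for cytotoxicity, read by LDH release, with a stated time of 15 h; on this read-out higher numbers stand for lower toxicity in this test and lower numbers for higher toxicity in this test. For compound 1 the entry reads "not determined" (no result reported) and so offers nothing to compare. Among the measured compounds shown here, compound 2 gives 76300 nM as the only number so far, which leaves it as a lone reference point with no neighbour to rank it against. Going by these compounds, compound 3 (`O=C(Nc1ccc(NCc2ccccc2)cc1Cl)c1cc(Cl)ccc1O`) is still untested. It differs from compound 2 by a single swap (phenyl in place of furan-2-yl on a saturated chain carbon bound to a nitrogen on an aromatic ring) with phenyl in place of furan-2-yl on a saturated chain carbon bound to a nitrogen on an aromatic ring. For the measured compounds named here, no measured pair shows what such a swap does in this assay so the expectation is a cautious one: a small drift toward lower numbers, perhaps no more than the usual scatter. An estimated step of a 1.4-fold lower number from compound 2 to compound 3 (0.14 log units; within the scatter) is what this expectation amounts to. The estimated value for compound 3 is 55000 nM with an expected range from 22000 nM to 110000 nM for this measurement.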

Compound 3, half-maximal cytotoxic concentration: 81300 nM
The estimate for compound 3 lay 1.5-fold (0.17 log units) below the measured number, within the range that was stated.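

In this assay, among the compounds shown here, the first measured pair at this position gives a 1.1-fold higher number from compound 2 to compound 3 (0.03 log units; within the scatter), so compound 2 and compound 3 cannot be told apart in this test. The swap removes a five-membered aromatic ring with one hetero atom and one hydrogen-bond acceptor and puts in a six-membered aromatic ring of carbon only, yet on a saturated chain carbon bound to a nitrogen on an aromatic ring this exchange leaves no readable mark on the result in this single pair. Nothing available here explains why the two compounds read alike.

Still open, going by these compounds, is whether a different kind of group at this place, such as a carboxylic acid, an amine or a longer chain in place of the benzyl or (furan-2-yl)methyl group, would shift the number beyond the usual scatter of the test. For the compounds shown here, compound 1 has the entry "not determined" (no result reported), so no step involving it can be read, and a single pair cannot show whether the same swap would behave alike on another core.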